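Chloro to Bromo on the Meta-Substituted Aryl Ketone

A few compounds are considered here, and "the series" means these few. Any claim that something is new, unique, unknown or untested is made for them only; others in the source may bear on it.

Two hydroxamic acids sharing one core have been measured in an assay on isolated protein for inhibition of histone deacetylase HD1B (Zea mays); on this read-out higher numbers stand for weaker inhibition and lower numbers for stronger inhibition. Compound 1 `Cn1cc(/C=C/C(=O)c2ccccc2Cl)cc1/C=C/C(=O)NO` gives 1600 nM in this assay. Going by the values given here, compound 2 `Cn1cc(/C=C/C(=O)c2cccc(Cl)c2)cc1/C=C/C(=O)NO` gives 31400 nM, the highest of the two numbers; the one step from compound 1 to compound 2 is a 20-fold higher number from compound 1 to compound 2 (1.29 log units; beyond the scatter), a change of where the halogen sits on the aryl ketone.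

Compound 3 `Cn1cc(/C=C/C(=O)c2cccc(Br)c2)cc1/C=C/C(=O)NO` differs from compound 2 by bromo in place of chloro on an aromatic carbon. Among the compounds with values here, no measured step exchanges one halogen for another at the same position, so the change is without direct precedent here; the measured step concerns position, not identity, of the halogen and does not bear on it. The expected step from compound 2 to compound 3 in this assay is therefore a 1.0-fold lower number from compound 2 to compound 3 (0.02 log units; within the scatter), nothing beyond the scatter. Compound 3 is estimated at 30000 nM in this assay, within a range from 12000 nM to 80000 nM.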

Compound 3, half-maximal inhibitory concentration: 480 nM
Compound 3: middle estimate off by 63-fold (1.80 log units), on the high side; measured number below the stated range.
By their numbers in this assay, from the lowest: compound 3; then compound 1; then compound 2.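

The exchange of one halogen for another, which the earlier pair could not speak to, proves decisive at this place on the aromatic ring: in this assay it gives a 65-fold lower number from compound 2 to compound 3 (1.82 log units; beyond the scatter) and turns the weakest of the chloro pair into the compound with the lowest number. The earlier step had tied the lower number to the 2-chlorophenyl ketone, but a 3.3-fold lower number from compound 1 to compound 3 (0.52 log units; beyond the scatter) shows that the 3-bromophenyl ketone can pass it, so the position of the halogen does not settle the outcome alone. Going by these compounds alone, nothing available bears on why a single halogen exchange moves the number so far.

Going by these compounds, it remains open whether iodo, methyl or trifluoromethyl at the same place would continue this change or lose it. Whether bromo in place of chloro on compound 1 would lower its number also stays unanswered.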